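This account rests on a few compounds, and the source may have more. Where it says the series, first, only, none or still open, it means among the compounds named here.

The compounds were tested in an assay on HEK293 cells for agonist activity at vitamin D3 receptor (Homo sapiens), read by a beta-galactosidase reporter; a lower number here means that less compound is needed, a higher number that more compound is needed for the effect.

Compound 1 `CCCCCCOC(C)(C)[C@H](O)COc1ccc(C(CC)(CC)c2ccc(OC[C@@H](O)CO)c(C)c2)cc1C`: in this assay compound 1 gives only a limit, > 10000 nM.
Compound 2 `CCCCCCCCOC(C)(C)[C@@H](O)COc1ccc(C(CC)(CC)c2ccc(OC[C@@H](O)CO)c(C)c2)cc1C`: in this assay compound 2 is reported as "not active" (no number reported), without a number.
Compound 3 `CCC(CC)(c1ccc(OC[C@@H](O)CO)c(C)c1)c1ccc(OC[C@@H](O)C(C)(C)OCCCCCCCCO)c(C)c1`: in this assay compound 3 gives only a limit, > 3000 nM.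

Among the measured compounds shown here, compound 3 therefore stands at a limit, as does compound 1, while compound 2 carries no number at all; no measured compound reaches a measurable value. For the measured compounds named here, the only step among measured compounds that can be read at all is a step that the two limits leave unreadable from compound 1 to compound 3, and the two limits leave its size unreadable.

Compound 4 `CCCCCCCCOC(C)(C)[C@H](O)COc1ccc(C(CC)(CC)c2ccc(OC[C@@H](O)CO)c(C)c2)cc1C` differs from compound 3 as follows: hydrogen in place of hydroxy on a saturated chain carbon, eight bonds along the chain from an oxygen on a saturated carbon. Going by the values given here, no measured step bears directly on this change. Since compound 1 sits at the limit of > 10000 nM in this assay, at which 1 of the 3 values shown sits, and compound 3 at the limit of > 3000 nM in this assay, at which 1 of the 3 values shown sits, compound 4 is expected to sit at or beyond a limit as well, with a step that the limit leaves unreadable from compound 3 to compound 4 meaning no movement beyond the scatter into a measurable range. Compound 4 is thus estimated at 20000 nM, between 5000 nM and 100000 nM.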

Compound 4, half-maximal effective concentration: "not active" (no number reported)
Nothing numeric was reported for compound 4; the estimate stays without a comparison.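

Compound 4 carries no number, so no new step can be read from it, either against compound 3 or against compound 2, which also has no number: the fact that compounds 2 and 4 differ only in the configuration as drawn. The compounds shown leave open whether any change to this chain gives a measurable value.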